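Fluoro on the phenyl ring: the step to compound 4

This account rests on a few compounds, and the source may have more. Where it says the series, first, only, none or still open, it means among the compounds named here.

Compound 1 `N=C(NCCCc1c[nH]cn1)NCCC(c1ccccc1)c1ccccn1` is the parent of the three measured compounds. In a functional assay on cardiac atrium for agonist activity at histamine H2 receptor (Cavia porcellus) (a lower number here means a less potent compound, a higher number a more potent compound, by a factor of ten per unit of this negative logarithm), compound 1 gives 7.39, the lowest of the three numbers. Compound 2 `N=C(NCCCc1c[nH]cn1)NCCC(c1ccc(C(F)(F)F)cc1)c1ccccn1`, carrying trifluoromethyl in place of hydrogen on an aromatic carbon, gives 7.76; compound 3 `N=C(NCCCc1c[nH]cn1)NCCC(c1cccc(F)c1)c1ccccn1`, carrying fluoro in place of hydrogen on an aromatic carbon, gives 7.88. The two steps from the parent, a number 0.37 log units higher from compound 1 to compound 2 (beyond the scatter) and a number 0.49 log units higher from compound 1 to compound 3 (beyond the scatter), both lie beyond the scatter and point the same way, while the step of a number 0.12 log units higher from compound 2 to compound 3 (within the scatter) lies within it.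

Compound 4 `N=C(NCCCc1c[nH]cn1)NCCC(c1ccccn1)c1ccccc1F` is not yet measured. It differs from compound 1 by fluoro in place of hydrogen on an aromatic carbon. Of the measured steps, compound 3 is the closer case, a fluoro entering the same ring, and compound 2 adds a second case of a substituent on that ring moving the number the same way. Neither sits at the present place, ortho to a large group, so the expectation rests more on the shared direction than on an exact size. A modest rise is expected, a number 0.31 log units higher from compound 1 to compound 4 (beyond the scatter), of roughly the size seen with compound 2 and compound 3. Compound 4 is estimated at 7.7 in this assay, with a range from 7.3 to 8.1.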

Compound 4, negative logarithm of the half-maximal effective concentration: 7.46
Compound 4: the middle estimate sits 0.24 log units above what was measured, within the range that was stated.
By their numbers in this assay, from the lowest: compounds 1, 4, 2 and 3 (each within the scatter of the next, the first and the last beyond it).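

In this assay, fluoro on an aromatic carbon ortho to a large group does not reproduce the rise seen with the earlier ring substituents (a number 0.07 log units higher from compound 1 to compound 4 (within the scatter)). For the compounds shown here, the same entering atom therefore reads differently by place: 2-fluorophenyl against 3-fluorophenyl is the one new step beyond the scatter (a number 0.42 log units lower from compound 3 to compound 4 (beyond the scatter)), so the fluoro step from the parent cannot be carried from one ring place to another. The comparison with the 4-(trifluoromethyl)phenyl compound does not separate the two (a number 0.30 log units lower from compound 2 to compound 4 (within the scatter)), which leaves 2-fluorophenyl apart from 3-fluorophenyl but not from 4-(trifluoromethyl)phenyl. No measurement at hand bears on what lies behind the difference between these places.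

Open, as far as these compounds go, is whether chloro, methyl or methoxy on the carbon ortho to a large group would behave as fluoro does here or would move the number. Also open, from the compounds shown here alone, is whether 2,3-difluorophenyl would follow 3-fluorophenyl or 2-fluorophenyl, which would show which of the two places governs when both carry fluoro.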